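The source may report more compounds than this note shows. Statements on the series, on what has been measured and on what is new or still open speak of the compounds shown alone.

Measured compounds:
Compound 1 `Cc1ccc(/C=C2\CCC/C(=C\c3cccc([N+](=O)[O-])c3)C2=O)cc1` gives 10100 nM in a functional assay on CCRF-CEM cells (Homo sapiens) for cytotoxicity, with a stated time of 72 h; on this read-out lower numbers stand for stronger inhibition and higher numbers for weaker inhibition.
Compound 2 `O=C1/C(=C/c2ccccc2)CCC/C1=C\c1cccc([N+](=O)[O-])c1` gives 2290 nM in this assay.

Within the data shown here, compound 2 stands lowest of the two numbers so far in this assay, and the only neighbour is compound 1, which sits higher by a step beyond the scatter. Among the measured compounds shown here, the one measured step, a 4.4-fold lower number from compound 1 to compound 2 (0.64 log units; beyond the scatter), comes from a hydrogen in place of methyl on an aromatic carbon of the same phenyl ring that compound 3 alters.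

Compound 3 `O=C1/C(=C/c2ccc(Cl)cc2)CCC/C1=C\c1cccc([N+](=O)[O-])c1` is not yet measured. It differs from compound 2 by chloro in place of hydrogen on an aromatic carbon. The step from compound 1 to compound 2 bears on this change only loosely, since it shows that a substituent at that aromatic carbon gave a higher number, but it says nothing about chloro itself. Compound 3 is therefore expected to show a small rise, perhaps within the scatter, a 1.4-fold higher number from compound 2 to compound 3 (0.15 log units; within the scatter), and its estimated value is 3200 nM, with a range from 1200 nM to 8500 nM.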

Compound 3, half-maximal inhibitory concentration in the CCRF-CEM assay: 1750 nM
Compound 3: middle estimate off by 1.8-fold (0.26 log units), on the high side; the range from low to high includes it.
By their numbers in the CCRF-CEM assay, from the lowest: compounds 3 and 2 (each within the scatter of the next); then compound 1.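

In the CCRF-CEM assay, chloro on this aromatic carbon, para to a large group, gives a 1.3-fold lower number from compound 2 to compound 3 (0.12 log units; within the scatter), whereas chloro in place of methyl gives a 5.8-fold lower number from compound 1 to compound 3 (0.76 log units; beyond the scatter), so among these three compounds only the methyl of compound 1 stands apart, and a substituent at this carbon does not of itself bring a higher number. In a physicochemical assay for lipophilicity (on this read-out lower numbers stand for lower lipophilicity and higher numbers for higher lipophilicity), compound 2 gives 5.06 and compound 3 gives 5.06, so the same exchange also leaves this second read-out level, at no change at the digits printed from compound 2 to compound 3 (within the scatter). Nothing available here accounts for why methyl and chloro part in this way.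

Only hydrogen, methyl and chloro are shown on this carbon, so it remains open whether an amine, a carboxylic acid or a longer chain would side with methyl or with the other two. Going by these compounds, it also remains open whether chloro would behave alike on the other carbons of this ring.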